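Trimming the Chain Terminus: From Phenyl to Hydrogen

A few compounds are considered here, and "the series" means these few. Any claim that something is new, unique, unknown or untested is made for them only; others in the source may bear on it.

Three close analogues of a shared core have been measured in an assay on HEK293 cells for agonist activity at Toll-like receptor 8 (Homo sapiens), read by spectrophotometry; on this read-out higher numbers stand for an effect only at larger amounts of compound and lower numbers for an effect already at smaller amounts. Compound 1 `CCCCNc1nc(N)nc(C)c1CCCCc1ccccc1` gives 857 nM in this assay. Compound 2 `CCCCNc1nc(N)nc(C)c1CCCN1CCCCC1` gives 133 nM, and compound 3 `CCCCNc1nc(N)nc(C)c1CCCn1ccc2ccccc21` gives 1100 nM. Among these three numbers compound 1 sits second highest; its nearest neighbour is compound 3, whose number differs only within the scatter, while compound 2 lies furthest away, with a 6.4-fold lower number from compound 1 to compound 2 (0.81 log units; beyond the scatter), a change of piperidin-1-yl in place of benzyl on a saturated chain carbon, three bonds along the chain from an aromatic carbon.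

Compound 4 `CCCCNc1nc(N)nc(C)c1CCCC` differs from compound 1 in one place: hydrogen in place of phenyl on a saturated chain carbon, four bonds along the chain from an aromatic carbon. The same difference, cut one bond further out, reads benzyl to methyl. Among the measured compounds shown here, no measured step removes the terminal aromatic group outright, so the only guide is that the one replacement of this terminus so far, from compound 1 to compound 2, moved the number well beyond the scatter. The account therefore expects a step in this assay for compound 4 of a 2.3-fold higher number from compound 1 to compound 4 (0.37 log units; beyond the scatter), most likely toward a higher number. The estimate for compound 4 in this assay is 2000 nM, with a range from 600 nM to 7000 nM.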

Compound 4, half-maximal effective concentration: 780 nM
The estimate for compound 4 lay 2.6-fold (0.41 log units) above the measured number; the range from low to high includes it.
By their numbers in this assay, from the lowest: compound 2; then compounds 4, 1 and 3 (each within the scatter of the next).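

In this assay the chain end at this place, on a saturated chain carbon four bonds along the chain from an aromatic carbon, takes hydrogen in place of phenyl with a 1.1-fold lower number from compound 1 to compound 4 (0.04 log units; within the scatter) and so the read-out does not separate a chain ending in phenyl from one ending without it. Set against this plain chain end, piperidin-1-yl still stands apart, at a 5.9-fold higher number from compound 2 to compound 4 (0.77 log units; beyond the scatter) and so the low number that piperidin-1-yl gives is not merely the absence of a terminal phenyl but goes with the piperidine ring itself, while neither the phenyl nor the indole-bearing chain end is yet separated from the plain chain by these numbers alone. Nothing available here offers a measured explanation for either step.

The compounds shown leave open whether an open-chain amine such as diethylamino at the chain end would give a number like that of piperidin-1-yl, or whether a morpholine ring or a carboxylic acid there would do the same. They also leave open how a longer or shorter plain chain would read against the chain of compound 4.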